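Swapping furan-2-yl for 3-methylphenyl: working notes on the series

The compounds below may be only part of what the source reports. "The series", "measured", "known", "first", "only" and "open" are said of these compounds alone.

Values so far in a functional assay on HCT-15 cells (Homo sapiens) for cytotoxicity, read by ELISA, with a stated time of 4 days; a lower number here means a stronger inhibitor, a higher number a weaker inhibitor
- compound 1 `Cc1ccsc1-c1cc(-c2ccoc2)cc(-c2ccco2)n1` gives 640 nM
- compound 2 `Clc1ccc(-c2cc(-c3ccco3)cc(-c3ccc(Cl)s3)n2)cc1` gives 1080 nM
- compound 3 `Clc1ccc(-c2cc(-c3ccoc3)cc(-c3ccco3)n2)s1` gives 1280 nM

Compound 3 lies within the scatter of both other measured compounds, so these numbers set it apart from neither. The step under consideration leads to the unmeasured compound 4 `Cc1cccc(-c2cc(-c3ccoc3)cc(-c3ccc(Cl)s3)n2)c1`, and the difference is 3-methylphenyl in place of furan-2-yl on an aromatic carbon. In words, this is 3-methylphenyl in place of furan-2-yl on an aromatic carbon.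

Going by the values given here, only one measured step is available: a 2.0-fold higher number from compound 1 to compound 3 (0.30 log units; within the scatter). It stays within the scatter, but it exchanges a different group, so it bears on this change only loosely. Among the compounds with values here, no measured step replaces furan-2-yl. Compound 2 offers indirect guidance, though it differs from compound 4 in more than one place. Both carry a six-membered aromatic ring of carbon only together with a 5-chlorothiophen-2-yl group, and compound 2 gives 1080 nM, within the scatter of compound 3. On this thin evidence, no step beyond the scatter is expected in this assay, and no direction can be favoured. The expected change is a 1.2-fold lower number from compound 3 to compound 4 (0.07 log units; within the scatter). For compound 4 the estimated value is 1100 nM, with an expected range from 450 nM to 2600 nM.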

Compound 4, half-maximal inhibitory concentration: 880 nM
Compound 4: middle estimate off by 1.3-fold (0.10 log units), on the high side; the measured number falls inside the stated range.
By their numbers in this assay, from the lowest: compounds 1, 4, 2 and 3 (each within the scatter of the next).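

In this assay, going by these compounds alone, the step of a 1.5-fold lower number from compound 3 to compound 4 (0.16 log units; within the scatter) is the first measured replacement of furan-2-yl on this aromatic carbon, next to the ring nitrogen, and it stays within the scatter. With the 5-chlorothiophen-2-yl and furan-3-yl groups held in place, the exchange of a five-membered aromatic ring with 1 hetero atom for a six-membered aromatic ring of carbon only, going from 5 to 7 heavy atoms and from 1 hydrogen-bond acceptor to 0, therefore produces no readable change in this pair. No measurement on the compounds shown gives a reason for this result.

As far as these compounds go, how this position responds to a group of another kind, such as an amine, a carboxylic acid or a longer chain like n-butyl, remains open, as the groups seen there so far are all aromatic rings. From the compounds shown here alone, this exchange also rests on a single pair, so it remains open whether it would read the same with 3-methylthiophen-2-yl in place of the 5-chlorothiophen-2-yl group.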